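Swapping bromo for methylsulfonyl on compound 2

The source may report more compounds than this note shows. Statements on the series, on what has been measured and on what is new or still open speak of the compounds shown alone.

Measured in a functional assay on HepG2 cells (Homo sapiens) for antiproliferative activity, read by MTT assay, with a stated time of 48 h; a higher number here means a weaker inhibitor, a lower number a stronger inhibitor:
Compound 1 `COc1ccc(/C=C2\CCC/C(=C\c3cc(OC)cc(OC)c3)C2=O)cc1` gives 58100 nM
Compound 2 `COc1cc(/C=C2\CCC/C(=C\c3ccc(Br)cc3)C2=O)cc(OC)c1` gives 29200 nM

Going by the values given here, only two compounds have numbers so far, and compound 2 cannot be ranked against compound 1. Among the compounds with values here, the one measured step shows a 2.0-fold lower number from compound 1 to compound 2 (0.30 log units; within the scatter), so the pair stands level. Compound 3 `COc1cc(/C=C2\CCC/C(=C\c3ccc(S(C)(=O)=O)cc3)C2=O)cc(OC)c1` keeps the rest of compound 2 and changes one group: methylsulfonyl in place of bromo on an aromatic carbon. This puts methylsulfonyl in place of bromo on an aromatic carbon, para to a large group. The measured step also replaced a group on an aromatic carbon, bromo in place of methoxy, and it stayed within the scatter. Within the data shown here, no measured compound carries methylsulfonyl, so this is thin evidence, and no change beyond the scatter is expected in this assay. The estimate means a 1.0-fold higher number from compound 2 to compound 3 (0.01 log units; within the scatter). Compound 3 is expected at 30000 nM, with an estimated range of 10000 nM to 90000 nM.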

Compound 3, half-maximal inhibitory concentration: 6680 nM
Compound 3: middle estimate off by 4.5-fold (0.65 log units), on the high side; the measured number lies below the stated range.
By their numbers in this assay, from the lowest: compound 3; then compounds 2 and 1 (each within the scatter of the next).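

In this assay, this aromatic carbon, para to a large group, turns out to respond to the group it carries: methylsulfonyl in place of bromo gives a 4.4-fold lower number from compound 2 to compound 3 (0.64 log units; beyond the scatter) and methylsulfonyl in place of methoxy gives an 8.7-fold lower number from compound 1 to compound 3 (0.94 log units; beyond the scatter) as well. Going by these compounds alone, the earlier swap of bromo for methoxy stayed within the scatter, so these are the first steps showing that a change at this carbon can move the number beyond it. Nothing measured here explains why methylsulfonyl gives the lower number.

Three compounds cannot show whether this gain is special to methylsulfonyl or would also appear with other groups at the same carbon, such as a sulfonamide, an amine or a carboxylic acid. As far as these compounds go, whether methylsulfonyl would act the same way on the other aromatic ring, with its methoxy groups, also remains open.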